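The source may report more compounds than this note shows. Statements on the series, on what has been measured and on what is new or still open speak of the compounds shown alone.

Compound 3 `O=C1c2ccccc2S(=O)(=O)N1CCCCCN1CCN(c2ncccn2)CC1` carries a pyrimidin-2-yl group on the amine nitrogen of its six-membered ring. In an assay on HEK293 cells for displacement of a labelled ligand from 5-hydroxytryptamine receptor 6 (Homo sapiens) (a higher number here means a weaker inhibitor, a lower number a stronger inhibitor), compound 3 gives 7100 nM, the highest of the three numbers recorded for this series, so it is the weakest binder among them. Compound 1 `O=C1c2ccccc2S(=O)(=O)N1CCCCCN1CCN(c2ccc(Cl)cc2)CC1`, which bears a 4-chlorophenyl group at the same place, gives 703 nM in this assay, and compound 2 `O=C1c2ccccc2S(=O)(=O)N1CCCCCCN1CCN(c2cccc(Cl)c2Cl)CC1`, with a 2,3-dichlorophenyl group and a longer linking chain, gives 72 nM.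

Compound 4 `O=C1c2ccccc2S(=O)(=O)N1CCCCCN1CCN(c2cccc(Cl)c2Cl)CC1` differs from compound 3 in one place: 2,3-dichlorophenyl in place of pyrimidin-2-yl on an amine nitrogen in a ring. For the measured compounds named here, the only measured step that bears on this change is a 10-fold higher number from compound 1 to compound 3 (1.00 log units; beyond the scatter); read in the reverse direction it points to a clearly lower number when a chlorinated phenyl ring takes the place of the pyrimidin-2-yl group. Compound 2, which already carries the 2,3-dichlorophenyl group, sits at 72 nM, which supports the same direction. The expected step is therefore a 47-fold lower number from compound 3 to compound 4 (1.68 log units; beyond the scatter), well beyond the scatter. For compound 4 the estimated value in this assay is 150 nM, with a range from 40 nM to 600 nM.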

Compound 4, inhibition constant: 197 nM
Beside the measured number, compound 4's estimate is 1.3-fold (0.12 log units) below it, and the stated range covers the measured number.
By their numbers in this assay, from the lowest: compound 2; then compound 4; then compound 1; then compound 3.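

Placing 2,3-dichlorophenyl on the amine nitrogen instead of pyrimidin-2-yl brings a 36-fold lower number from compound 3 to compound 4 (1.56 log units; beyond the scatter) and is the largest single step measured at this position so far. The earlier compounds shown here showed only that 4-chlorophenyl gives a lower number than pyrimidin-2-yl, whereas a 3.6-fold lower number from compound 1 to compound 4 (0.55 log units; beyond the scatter) shows that the chlorinated phenyl rings are not interchangeable here, since the two rings give different numbers in this assay and the gap lies beyond the scatter. Nothing available explains why these changes move the number.

Compounds 1 and 4 differ in both the number and the placement of their chlorines, so these results cannot say which of the two matters. Going by these compounds, it also remains open how a plain phenyl ring, a 3-chlorophenyl ring or a 2-methoxyphenyl ring would compare at this nitrogen.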